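Nucleoside series: substituent on the chain carbon and maximal response

This account rests on a few compounds, and the source may have more. Where it says the series, first, only, none or still open, it means among the compounds named here.

Measured so far:
compound 1 `Nc1nc(O)c2c(n1)n(C1OC(CO)[C@@H](O)[C@H]1O)c(=O)n2CC(O)CO` gives 136% in a functional assay on the whole organism (B cells) with Mus musculus as the target; a lower number here means a smaller maximal response, a higher number a larger maximal response;
compound 2 `Cn1c(=O)n(C2OC(CO)[C@@H](O)[C@H]2O)c2nc(N)nc(O)c21` gives 99% in this assay.

Compound 2 stands lowest of the two numbers; its nearest neighbour is compound 1, which sits higher by a number 37 percentage points lower from compound 1 to compound 2 (beyond the scatter) read in reverse. Compound 3 `NCC(O)Cn1c(=O)n(C2OC(CO)[C@@H](O)[C@H]2O)c2nc(N)nc(O)c21` carries 2-amino-1-hydroxyethyl in place of hydrogen on a saturated chain carbon bound to an aromatic nitrogen. For the measured compounds named here, the one step that bears on this, a number 37 percentage points lower from compound 1 to compound 2 (beyond the scatter), shows a large loss where a related group on the same place was replaced by hydrogen; the reverse direction, growing a chain there again, is therefore expected to raise the maximal response, though the entering group is not the same one. The expected step is a number 26 percentage points higher from compound 2 to compound 3 (beyond the scatter), and compound 3 is estimated at 125% within 95% to 155%.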

Compound 3, largest response reached (reported as maximal response), in percent of the reference or control that the assay uses: 110%
Estimate against measurement, compound 3: 15 percentage points above, within the range that was stated.
By their numbers in this assay, from the lowest: compound 2; then compound 3; then compound 1.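

Adding 2-amino-1-hydroxyethyl in place of hydrogen on a saturated chain carbon bound to an aromatic nitrogen gives a number 11 percentage points higher from compound 2 to compound 3 (beyond the scatter) in this assay, so this chain also raises the maximal response, not only the one carried by compound 1. Amino in place of hydroxy on a saturated chain carbon gives a number 26 percentage points lower from compound 1 to compound 3 (beyond the scatter), so the response depends on what the chain carries as well as on its presence. No available evidence bears on either step.

The compounds shown leave open how a carboxylic acid or a methoxy group in place of that amino would read, and whether a longer chain carrying the same amino would reach compound 1.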